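A few compounds are considered here, and "the series" means these few. Any claim that something is new, unique, unknown or untested is made for them only; others in the source may bear on it.

In a functional assay on MCF7 cells (Homo sapiens) for antiproliferative activity, read by MTT assay, with a stated time of 48 h (on this read-out lower numbers stand for stronger inhibition and higher numbers for weaker inhibition), compound 2 `O=C(/C=C/c1ccccc1)Nc1nnc(-c2ccccc2)s1` gives 1.47 ug/mL, and compound 1 `Cc1ccc(/C=C/C(=O)Nc2nnc(-c3ccc(Cl)cc3)s2)cc1` gives 1.44 ug/mL. Among the compounds with values here, these are the only two measurements so far. They lie within the scatter of each other, so compound 2 cannot be ranked against compound 1 on these numbers.

The next compound to be tested is compound 3 `O=C(/C=C/c1ccc(F)cc1)Nc1nnc(-c2ccccc2)s1`, which differs from compound 2 at a single place: fluoro in place of hydrogen on an aromatic carbon. The same difference can also be read as phenyl to 4-fluorophenyl.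

Within the data shown here, no pair of measured compounds differs in just one place, so the data give no direct measure of what a single change of this kind does. With so little evidence, no direction is favoured in this assay, and no step beyond the scatter is expected. The estimated change is a 1.1-fold lower number from compound 2 to compound 3 (0.02 log units; within the scatter). For compound 3 the expected value is 1.4 ug/mL, with an estimated range from 0.6 ug/mL to 3.2 ug/mL.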

Compound 3, half-maximal inhibitory concentration: 1.45 ug/mL
Beside the measured number, compound 3's estimate is 1.0-fold (0.02 log units) below it, and the stated range covers the measured number.
By their numbers in this assay, from the lowest: compounds 1, 3 and 2 (each within the scatter of the next).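

Fluoro in place of hydrogen, on an aromatic carbon para to a large group, gives a 1.0-fold lower number from compound 2 to compound 3 (0.01 log units; within the scatter) in this assay. This is the first pair shown that differs in just one place, so it gives a direct reading of a single change: phenyl to 4-fluorophenyl at this position leaves compound 2 and compound 3 indistinguishable on this read-out, and adding one fluorine atom here does not cost measurable activity. No separate measurement bears on why the two compounds read alike.

As far as these compounds go, a single small atom at one position says little about larger or different groups, so it remains open whether an amine or a carboxylic acid in place of the same hydrogen would also leave the number within the scatter. From the compounds shown here alone, it also remains open whether fluoro would read the same at another carbon of this ring, or on the other phenyl ring of the shared core.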